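Adding methoxymethyl to compound 2

This account rests on a few compounds, and the source may have more. Where it says the series, first, only, none or still open, it means among the compounds named here.

In an ADME assay on RAW264.7 cells (Mus musculus) for cytotoxicity, read by MTT assay, with a stated time of 24 h (a higher number here means that more compound is tolerated, a lower number that less compound is tolerated), compound 2 `CC/C=C\C[C@H]1C(=O)C=C[C@H]1CC(=O)OCCOCCOC` gives 161 uM and compound 1 `CC/C=C\C[C@H]1C(=O)C=C[C@H]1CC(=O)OCCOCCOCCO` gives 162 uM as its value, so the two stand within the usual scatter of each other. Compound 3 `CC/C=C\C[C@H]1C(=O)C=C[C@H]1CC(=O)OCCOCCOCCOC` differs from compound 2 by methoxymethyl in place of hydrogen on a saturated chain carbon bound to an oxygen on a saturated carbon and carries methoxymethyl in place of hydrogen on a saturated chain carbon bound to an oxygen on a saturated carbon. Going by the values given here, the one measured step at this place is a 1.0-fold lower number from compound 1 to compound 2 (0.00 log units; within the scatter) and it stays within the scatter. No step beyond the scatter is therefore expected in this assay and the estimated step is a 1.0-fold lower number from compound 2 to compound 3 (0.00 log units; within the scatter) in size. Compound 3 is expected at 160 uM (estimated range 95 uM to 260 uM).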

Compound 3, half-maximal toxic concentration: 163 uM
The estimate for compound 3 lay 1.0-fold (0.01 log units) below the measured number; the measured number falls inside the stated range.
By their numbers in this assay, from the lowest: compounds 2, 1 and 3 (each within the scatter of the next).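

In this assay, methoxymethyl in place of hydrogen on a saturated chain carbon bound to an oxygen on a saturated carbon gives a 1.0-fold higher number from compound 2 to compound 3 (0.01 log units; within the scatter), so lengthening the chain by this unit brings no measurable change. Methyl in place of hydrogen on an oxygen on a saturated carbon gives a 1.0-fold higher number from compound 1 to compound 3 (0.00 log units; within the scatter), so capping the end hydroxyl also leaves the number within the scatter. On these data alone, whether an amine or a carboxylic acid at the chain end would move the number stays open. Nothing available explains why these numbers stay together.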